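Cyano in place of nitro on the aromatic ring

The source may hold more compounds than are shown below. What is called first, only, known or untested is meant among the compounds shown, and "the series" means these compounds.

In a functional assay on PANC-1 cells (Homo sapiens) for antiproliferative activity, read by CCK-8 assay, with a stated time of 72 h (a lower number here means a stronger inhibitor, a higher number a weaker inhibitor), compound 1 `Cc1cc(Nc2cc(N3CCN(C)CC3)nc(Nc3ccc(S(N)(=O)=O)cc3)n2)n[nH]1` gives 8760 nM and compound 2 `Cc1cc(Nc2cc(N3CCN(C)CC3)nc(Nc3ccc([N+](=O)[O-])cc3)n2)n[nH]1` gives 442 nM, the lower of the two numbers. Compound 3 `Cc1cc(Nc2cc(N3CCN(C)CC3)nc(Nc3ccc(C#N)cc3)n2)n[nH]1` differs from compound 2 as follows: cyano in place of nitro on an aromatic carbon. This places cyano in place of nitro on an aromatic carbon, para to a large group. For the measured compounds named here, only one measured step bears on this carbon: a 20-fold lower number from compound 1 to compound 2 (1.30 log units; beyond the scatter), a large step on replacing sulfamoyl with nitro. That step shows the site matters in this assay, but it does not involve cyano, so only a modest rise is expected. The expected step is a 1.8-fold higher number from compound 2 to compound 3 (0.26 log units; within the scatter). For compound 3 the estimated value is 800 nM, with an expected range of 250 nM to 2800 nM.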

Compound 3, half-maximal inhibitory concentration: 435 nM
Estimate against measurement, compound 3: 1.8-fold (0.26 log units) above; measured number inside the range.
By their numbers in this assay, from the lowest: compounds 3 and 2 (each within the scatter of the next); then compound 1.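

In this assay the change to cyano gives a 1.0-fold lower number from compound 2 to compound 3 (0.01 log units; within the scatter) and so leaves the number where nitro had it. Against sulfamoyl, cyano gives a 20-fold lower number from compound 1 to compound 3 (1.30 log units; beyond the scatter) and matches the step seen with nitro, so at this carbon the large step goes with leaving sulfamoyl and does not depend on nitro itself. Nothing on hand explains why cyano and nitro read alike here.

Still open, as far as these compounds go, is whether an amine, a carboxylic acid or a chlorine on this carbon would stay level with compound 2 and compound 3 or fall back towards compound 1. Also open, from the compounds shown here alone, is whether plain hydrogen there would do as well.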